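Three limits on the shared core and a fourth compound

A few compounds are considered here, and "the series" means these few. Any claim that something is new, unique, unknown or untested is made for them only; others in the source may bear on it.

The shared core of compound 1 `Cc1cc(C)c2cccc(OCc3c(Cl)ccc(S(=O)(=O)NC4(C(=O)N5CCN(C(=O)[C@H](CCCCN)[N+](C)(C)C)CC5)CCCC4)c3Cl)c2n1` carries, on a carbonyl carbon of the side chain, a group of 10 heavy atoms; in an assay on isolated protein for binding affinity to B1 bradykinin receptor (Homo sapiens) (on this read-out higher numbers stand for weaker inhibition and lower numbers for stronger inhibition), compound 1 gives only a limit of < 10000 nM. Compound 2 `Cc1cc(C)c2cccc(OCc3c(Cl)ccc(S(=O)(=O)NC4(C(=O)N5CCN(C(=O)C[C@@H](N)CCC[N+](C)(C)C)CC5)CCCC4)c3Cl)c2n1` keeps this core and in this assay gives likewise only a limit of < 10000 nM. Compound 3 `Cc1cc(C)c2cccc(OCc3c(Cl)ccc(S(=O)(=O)NC4(C(=O)N5CCN(C(=O)[C@@H](N)CC[N+](C)(C)C)CC5)CCCC4)c3Cl)c2n1` carries a smaller group on the same carbonyl carbon, and in this assay compound 3 gives only a limit of < 10000 nM. The three steps that join these compounds, a step that the two limits leave unreadable from compound 1 to compound 2, a step that the two limits leave unreadable from compound 1 to compound 3 and a step that the two limits leave unreadable from compound 2 to compound 3, therefore carry no readable size, because all three values sit at the limit of < 10000 nM in this assay, at which 3 of the 3 values shown sit.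

Compound 4 `Cc1cc(C)c2cccc(OCc3c(Cl)ccc(S(=O)(=O)NC4(C(=O)N5CCN(C(=N)NCCC[N+](C)(C)C)CC5)CCCC4)c3Cl)c2n1` differs from compound 3 by a group of 10 heavy atoms (7 carbon, 3 nitrogen; no ring) in place of a group of 10 heavy atoms (7 carbon, 2 nitrogen, 1 oxygen; no ring), on an amine nitrogen in a ring. Going by the values given here, no measured step touches this position, and the three steps that exist between compounds 1, 2 and 3 are all unreadable, so no direction or size can be taken from them. Among the compounds with values here, the only evidence is that every value so far sits at the limit, which for compound 4 is expected to hold as well, with the step that the limit leaves unreadable from compound 3 to compound 4 meaning no readable change. In this assay compound 4 is thus expected near 500 nM, within a range from 10 nM to 9000 nM.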

Compound 4, inhibition constant: < 10000 nM
Compound 4 was reported as a limit (the forecaster's own chance of this, stated with the estimate: 70%); the middle value is on the limit's open side.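

In this assay compound 4 gives < 10000 nM, which is a limit. Its steps from compound 1, compound 2 and compound 3 cannot be read, because all the values share one limit: the limit of < 10000 nM in this assay, at which 4 of the 4 values shown sit.

The compounds shown leave open how strong each one's inhibition is and whether changing the group on the ring nitrogen alters it.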